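The compounds below may be only part of what the source reports. "The series", "measured", "known", "first", "only" and "open" are said of these compounds alone.

Compound 1 `C/C=C/COC(=O)/C=C(C)/C=C/CC(C)CCCC(C)(C)OC` and compound 2 `CCOC(=O)/C=C(C)/C=C/CC(C)CCC(=O)C(C)C` have each been examined in a physicochemical assay for lipophilicity; on this read-out lower numbers stand for lower lipophilicity and higher numbers for higher lipophilicity. Compound 1 gives 6.07, the higher of the two numbers, and compound 2 gives 4.3, a gap that lies beyond the usual scatter of repeated measurements. Compound 3 `CCC(=O)/C=C(C)/C=C/CC(C)CCCC(C)(C)OC` has not yet been measured in this assay. It differs from compound 1 in a single place: ethyl in place of (but-2-en-1-yl)oxy on a carbonyl carbon. Cut one bond further out, the same change reads as ((but-2-en-1-yl)oxy)carbonyl giving way to propanoyl. Among the measured compounds shown here, no pair of measured compounds shares this exact step, so the expectation rests on the change itself and on where compound 1 stands. Because compound 1 sits at 6.07 while the leaving group carries a hydrogen-bond acceptor and the entering ethyl carries none, a downward step of a number 0.87 log units lower from compound 1 to compound 3 (beyond the scatter) is expected. Compound 3 is therefore estimated at 5.2, with a likely range from 4.6 to 5.8.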

Compound 3, partition coefficient: 5.07
Beside the measured number, compound 3's estimate is 0.13 log units above it, and the stated range covers the measured number.
By their numbers in this assay, from the lowest: compound 2; then compound 3; then compound 1.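

In this assay the read-out shows a number 1.00 log units lower from compound 1 to compound 3 (beyond the scatter) when ethyl takes the place of (but-2-en-1-yl)oxy on a carbonyl carbon, with the rest of the molecule unchanged. Among the compounds shown here, this is the only comparison here that ties a shift in the number to one place, since compound 1 and compound 2 differ in more than one. The leaving group is larger than ethyl and also holds an oxygen and a double bond, but nothing shown explains the step or says which of these features matters.

From the compounds shown here alone, what remains open is how the number would respond to other groups on that carbonyl carbon, such as a butyl chain, which has no oxygen, or an amine. Going by these compounds, whether the step would keep its size on a different remainder of the molecule also remains unknown.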